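Three Heteroaryl Analogues That Sit at the Assay Limit

This account rests on a few compounds, and the source may have more. Where it says the series, first, only, none or still open, it means among the compounds named here.

Compound 3 `Oc1ccccc1-c1cc(-c2ccccn2)cc(-c2ccccc2O)n1` carries a pyridin-2-yl group on the shared core. In a functional assay on HCT-15 cells (Homo sapiens) for cytotoxicity, read by CCK-8 assay (on this read-out higher numbers stand for weaker inhibition and lower numbers for stronger inhibition), compound 3 gives > 50000 nM, which is a limit of the assay and not a number. Its two measured relatives stand in the same place. Compound 1 `Oc1ccccc1-c1cc(-c2ccsc2)cc(-c2ccccc2O)n1` gives > 50000 nM in this assay, again a limit. Compound 2 `Oc1ccccc1-c1cc(-c2ccco2)cc(-c2ccccc2O)n1` gives > 50000 nM in this assay, also a limit. The steps a step that the two limits leave unreadable from compound 1 to compound 2, a step that the two limits leave unreadable from compound 1 to compound 3 and a step that the two limits leave unreadable from compound 2 to compound 3 therefore cannot be sized, since all three values rest on (the limit of > 50000 nM in this assay, at which 3 of the 3 values shown sit).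

Compound 4 `Oc1ccccc1-c1cc(-c2cccnc2)cc(-c2ccccc2O)n1` has not yet been measured. The change from compound 3 is pyridin-3-yl in place of pyridin-2-yl on an aromatic carbon. Going by the values given here, the three measured steps bear on this step only in the sense that every exchange of the group at this place so far has left the read-out at the limit, so no movement beyond the scatter is expected in this assay, and a further limit is the most likely result. Compound 4 is expected to give about 70000 nM, within a range of 20000 nM to 300000 nM. The step that the limit leaves unreadable from compound 3 to compound 4 is accordingly estimated to be nothing beyond the scatter.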

Compound 4, half-maximal inhibitory concentration: > 50000 nM
Compound 4 gave a limit, no number (the forecaster's own chance of this, stated with the estimate: 85%); the middle value is on the limit's open side.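

In this assay compound 4 gives > 50000 nM, which is a limit of the assay and not a number. Going by these compounds alone, no step among compound 1, compound 2, compound 3 and compound 4 can be read, since all four values rest on one limit: the limit of > 50000 nM in this assay, at which 4 of the 4 values shown sit. The compounds shown leave open whether any group at this place on the shared core gives a measurable value in this assay.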